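A Chlorobenzyl Sulfide on the Dimethoxybenzylidene Core

The source may report more compounds than this note shows. Statements on the series, on what has been measured and on what is new or still open speak of the compounds shown alone.

Compound 3 `COc1ccc(/C=N/n2c(SC)nnc2-c2cc(OC)c(OC)c(OC)c2)c(OC)c1` was tested in a functional assay on MKN-45 cells (Homo sapiens) for cytotoxicity, read by MTT assay, with a stated time of 48 h; a higher number here means a weaker inhibitor, a lower number a stronger inhibitor. For compound 3 the result is a limit of the assay, > 200000 nM, and not a number. Two of the three values reported here sit at that limit (the limit of > 200000 nM in this assay, at which 2 of the 3 values shown sit). Compound 1 `COc1cc(-c2nnc(SC)n2/N=C/c2ccccc2)cc(OC)c1OC` gives 28500 nM in this assay. Compound 2 `COc1cc(-c2nnc(SCc3ccccc3)n2/N=C/c2ccccc2)cc(OC)c1OC` reaches only a limit, > 200000 nM, in this assay. Compound 4 `COc1ccc(/C=N/n2c(SCc3ccccc3Cl)nnc2-c2cc(OC)c(OC)c(OC)c2)c(OC)c1` differs from compound 3 by 2-chlorophenyl in place of hydrogen on a saturated chain carbon bound to a sulfur. The measured step that bears most directly on this change is an at least 7.0-fold higher number from compound 1 to compound 2 (0.84 log units; beyond the scatter), where a phenyl entered at the same place on the sulfur-bound carbon. The step of an at least 7.0-fold higher number from compound 1 to compound 3 (0.84 log units; beyond the scatter) shows that compound 3 already stands at the edge of what this assay can report. A further rise from there cannot be read as a number, so no step beyond the scatter is expected to become visible, and the estimated step is a step that the limit leaves unreadable from compound 3 to compound 4. Compound 4 is expected to give 300000 nM, between 100000 nM and 2000000 nM, most likely again as a limit in this assay.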

Compound 4, half-maximal inhibitory concentration: > 200000 nM
Compound 4 gave a limit, no number (the forecaster's own chance of this, stated with the estimate: 85%); the middle value lies beyond the limit too.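

Compound 3 and compound 4 both stop at a limit and not a number in this assay, so no step between them can be read: the limit of > 200000 nM in this assay, at which 3 of the 4 values shown sit.

The compounds shown leave open whether 2-chlorophenyl in place of hydrogen changes the result at all.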